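The compounds below may be only part of what the source reports. "The series", "measured", "known", "first", "only" and "open" are said of these compounds alone.

Of the compounds shown here, three have been tested in a functional assay on NCI-H522 cells (Homo sapiens) for cytotoxicity, read by sulforhodamine B assay, with a stated time of 48 h; on this read-out higher numbers stand for weaker inhibition of growth and lower numbers for stronger inhibition of growth. Compound 1 `ClCc1ccc(Cn2cnc3c(Cl)ncnc32)cc1` gives 3540 nM in this assay. Compound 2 `ClCc1cccc(Cn2cnc3ncnc(Cl)c32)c1` is built from the same atoms joined differently; how its core differs from that of compound 1 is not broken down here. In this assay compound 2 gives 6160 nM. Compound 3 `ClCc1ccc(Cn2cnc3c(Cl)nc(Cl)nc32)cc1` carries one change relative to compound 1, (chloro in place of hydrogen on an aromatic carbon), and in this assay compound 3 gives 22400 nM. Within the data shown here, the step of a 6.3-fold higher number from compound 1 to compound 3 (0.80 log units; beyond the scatter) is the one comparison so far that shows what adding this chloro group does.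

Compound 4 `ClCc1cccc(Cn2cnc3nc(Cl)nc(Cl)c32)c1` has not yet been measured. It differs from compound 2 by chloro in place of hydrogen on an aromatic carbon, the same change as that from compound 1 to compound 3, at a place described in the same words. On this basis the step from compound 2 to compound 4 is expected to resemble the earlier one, about a 5.7-fold higher number from compound 2 to compound 4 (0.75 log units; beyond the scatter), because compound 3 stands at a 6.3-fold higher number from compound 1 to compound 3 (0.80 log units; beyond the scatter) relative to compound 1. For compound 4 the expected value in this assay is 35000 nM, with a likely range from 12000 nM to 90000 nM.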

Compound 4, concentration for 50% growth inhibition: 1810 nM
Estimate against measurement, compound 4: 19-fold (1.29 log units) above; the whole stated range lies above it.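

In this assay, putting chloro in place of hydrogen gives a 3.4-fold lower number from compound 2 to compound 4 (0.53 log units; beyond the scatter), so growth inhibition grows stronger here, whereas the same change weakened it on the core of compound 1. Set side by side, the two steps run in opposite directions and do not agree: the same change on two cores in this assay, a 6.3-fold higher number (0.80 log units; beyond the scatter) from compound 1 to compound 3 and a 3.4-fold lower number (0.53 log units; beyond the scatter) from compound 2 to compound 4, 22-fold (1.33 log units) apart, beyond the scatter of two such steps In this series, then, the effect of this chloro group does not carry over from the core of compound 1 to the core of compound 2, but with only one pair on each core, this does not show why the two differ or how a further core would respond.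

The compounds shown carry only hydrogen or chloro at this place between two ring nitrogen atoms, so it remains open how an amine, a methoxy group or a longer chain there would behave on either core. As far as these compounds go, whether the two cores would part in the same way in another cell line also remains open.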